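The source may report more compounds than this note shows. Statements on the series, on what has been measured and on what is new or still open speak of the compounds shown alone.

Working notes on the series. Compound 1 `Cc1nnc(COc2cnn(C(C)(C)C)c(=O)c2Cl)o1` is the smallest member, and in a functional assay on the whole organism for inhibition, with Mythimna separata as the target, with a stated time of 5 days (a higher number here means that more compound is needed for the effect, a lower number that less compound is needed), compound 1 returns only a limit, > 299000 nM. Compound 2 `Cc1cc(C)cc(-c2nnc(COc3cnn(C(C)(C)C)c(=O)c3Cl)o2)c1` carries 3,5-dimethylphenyl in place of methyl on an aromatic carbon. In this assay compound 2 likewise returns a limit, > 299000 nM. Compound 3 `CC(C)(C)n1ncc(OCc2nnc(-c3cc(F)c(Cl)c([N+](=O)[O-])c3Cl)o2)c(Cl)c1=O` in this assay also stops at a limit, > 299000 nM. The step that the two limits leave unreadable from compound 1 to compound 2 is accordingly not readable, and compound 2 stands where every measured member stands, at the limit of > 299000 nM in this assay, at which 3 of the 3 values shown sit.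

Compound 4 `CC(C)(C)n1ncc(OCc2nnc(-c3ccc(F)cc3)o2)c(Cl)c1=O` differs from compound 2 by 4-fluorophenyl in place of 3,5-dimethylphenyl on an aromatic carbon. For the measured compounds named here, the one step on hand, a step that the two limits leave unreadable from compound 1 to compound 2, gives no size, and none of the three measured compounds yields a number from which a direction could be read. The change from compound 2 to compound 4 is therefore taken as a step of no readable size in either direction, and another limit is the most likely outcome. The step expected in this assay is a step that the limit leaves unreadable from compound 2 to compound 4. In this assay compound 4 is estimated at 300000 nM, with a range from 60000 nM to 1500000 nM.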

Compound 4, half-maximal effective concentration: 5200 nM
The estimate for compound 4 lay 58-fold (1.76 log units) above the measured number, outside the stated range (below it).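

In this assay, the group on an aromatic carbon of a five-membered aromatic ring with 2 nitrogen and 1 oxygen now proves able to move the read-out: 4-fluorophenyl in place of 3,5-dimethylphenyl gives an at least 57-fold lower number from compound 2 to compound 4 (1.75 log units; beyond the scatter), and 4-fluorophenyl in place of methyl gives an at least 57-fold lower number from compound 1 to compound 4 (1.75 log units; beyond the scatter). Both steps start from a limit, and each fixes a minimum size only. A six-membered aromatic ring of carbon only is not enough at this place, since compound 2 also has one and stays at a limit, while compound 4 is the one member with a number: the limit of > 299000 nM in this assay, at which 3 of the 4 values shown sit.

Going by these compounds, it remains open whether the fluorine, its place on the ring or the loss of the two methyl groups carries the step, and compound 3, which also has fluorine on its ring yet stays at a limit, goes against any reading by fluorine alone. Also open, on these data alone, is how plain phenyl, 4-chlorophenyl, 4-methoxyphenyl or an amine at this place would read in this assay.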